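From Nitro to Chloro on Compound 1

The compounds below may be only part of what the source reports. "The series", "measured", "known", "first", "only" and "open" are said of these compounds alone.

Compound 1 `C=C(CC)C(=O)c1ccc(OCC(=O)Nc2ccc(O)c([N+](=O)[O-])c2)c(Cl)c1Cl`: 7400 nM
Compound 2 `C=C(CC)C(=O)c1ccc(OCC(=O)Nc2ccc3cc(C(=O)O)ccc3c2)c(Cl)c1Cl`: 3700 nM

Both numbers come from a functional assay on CLL cells (Homo sapiens) for cytotoxicity, read by MTT assay, with a stated time of 48 h; on this read-out lower numbers stand for an effect already at smaller amounts and higher numbers for an effect only at larger amounts of compound. For the measured compounds named here, compound 1 stands at 7400 nM, and its only neighbour on this scale is compound 2 at 3700 nM. These two values lie within the usual scatter of repeated measurements, so they cannot be ranked. The two structures differ in more than one place, so this pair does not isolate the effect of any single change.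

Compound 3 `C=C(CC)C(=O)c1ccc(OCC(=O)Nc2ccc(O)c(Cl)c2)c(Cl)c1Cl` has not yet been measured. It departs from compound 1 in a single place: chloro in place of nitro on an aromatic carbon. This puts chloro in place of nitro on an aromatic carbon, ortho to a hydroxy group. Going by the values given here, no measured pair shows what a single swap of this kind does, so the data offer no guide to its direction. The estimate therefore starts from compound 1 at 7400 nM, and no shift beyond the scatter is expected. The expected change is a 1.2-fold lower number from compound 1 to compound 3 (0.09 log units; within the scatter). For compound 3, the estimated value is 6000 nM, with an expected range from 2500 nM to 14000 nM.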

Compound 3, half-maximal effective concentration: 5500 nM
Estimate against measurement, compound 3: 1.1-fold (0.04 log units) above; low and high end bracket the measured number.
By their numbers in this assay, from the lowest: compounds 2, 3 and 1 (each within the scatter of the next).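

In this assay, for the compounds shown here, the swap of nitro for chloro gives a 1.3-fold lower number from compound 1 to compound 3 (0.13 log units; within the scatter) and this is the first comparison here that isolates a single place on the molecule. On this aromatic carbon, ortho to a hydroxy group, 3 heavy atoms with 2 hydrogen-bond acceptors leave and 1 heavy atom with no hydrogen-bond acceptors enters, yet the two compounds cannot be told apart on this read-out, so the nitro group is not needed here to keep the cytotoxicity seen for compound 1. Nothing measured here explains why these two groups read alike.

With only nitro and chloro shown at this position, it remains open whether an amine, a carboxylic acid, a methoxy group or a plain hydrogen on the same carbon would also stay within the scatter or would move the number clearly in either direction. Going by these compounds, compound 1 and compound 3 also both carry the hydroxy group, so what a methoxy group in its place would do stays open as well.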